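A few compounds are considered here, and "the series" means these few. Any claim that something is new, unique, unknown or untested is made for them only; others in the source may bear on it.

Measured in a functional assay on the whole organism with Scenedesmus acutus as the target, read by spectrophotometry; a lower number here means a stronger inhibitor, a higher number a weaker inhibitor:
- compound 1, `COC(=O)CSc1cc(-n2c(=S)n3n(c2=S)CCCC3)c(F)cc1Cl`: compound 1 gives 141 nM
- compound 2, `C#CCOc1cc(-n2c(=S)n3n(c2=S)CCCC3)c(F)cc1Cl`: compound 2 gives 1.7 nM
- compound 3, `COC(=O)CSc1cc(/N=c2\sc(=S)n3n2CCCC3)c(F)cc1Cl`: compound 3 gives 191 nM

The only single-point step among these is an 83-fold lower number from compound 1 to compound 2 (1.92 log units; beyond the scatter), the change being (propargyloxy in place of ((methoxycarbonyl)methyl)sulfanyl on an aromatic carbon). Compound 3 has the same atoms as compound 1 joined differently; the difference between the two cores is not broken down here. Its value and that of compound 1 lie within the usual scatter of each other.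

Compound 4, `C#CCOc1cc(/N=c2\sc(=S)n3n2CCCC3)c(F)cc1Cl`, is not yet measured. It differs from compound 3 by propargyloxy in place of ((methoxycarbonyl)methyl)sulfanyl on an aromatic carbon, the same change as that from compound 1 to compound 2, at a place described in identical words. For compound 4 a step of a 64-fold lower number from compound 3 to compound 4 (1.80 log units; beyond the scatter) is expected, somewhat smaller than the earlier one because the same change gave an 83-fold lower number from compound 1 to compound 2 (1.92 log units; beyond the scatter) on a different core. Compound 4 is estimated at 3 nM, between 1 nM and 12 nM.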

Compound 4, half-maximal inhibitory concentration: 5.5 nM
For compound 4 the middle estimate is 1.8-fold (0.26 log units) below the measured one; measured number inside the range.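

In this assay, propargyloxy in place of ((methoxycarbonyl)methyl)sulfanyl gives a 35-fold lower number from compound 3 to compound 4 (1.54 log units; beyond the scatter), so the large step seen on the core of compound 1 also appears on the core of compound 3. The two steps agree on the two cores: the same change on two cores in this assay, an 83-fold lower number (1.92 log units; beyond the scatter) from compound 1 to compound 2 and a 35-fold lower number (1.54 log units; beyond the scatter) from compound 3 to compound 4, 2.4-fold (0.38 log units) apart, within the scatter of two such steps. Among the compounds shown here, this rests on only two matched pairs and one exchange of groups in a single whole-organism assay, so it does not show that other changes would transfer between these cores, nor why this change lowers the number.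

Still open, as far as these compounds go, is where an allyloxy group, a methoxy group or an amine at this aromatic carbon would stand on either core. The compounds shown also leave open whether the step would hold with another group in place of the chloro or fluoro group.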